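The compounds below may be only part of what the source reports. "The series", "measured", "known", "first", "only" and "open" are said of these compounds alone.

Within the data shown here, compound 2 `O=C1C(=O)N(CN2CCN(c3ccnc4cc(Cl)ccc34)CC2)c2ccccc21` gives the highest of the two numbers so far in a functional assay on MCF7 cells (Homo sapiens) for cytotoxicity, read by sulforhodamine B assay, with a stated time of 48 h (a lower number here means a stronger inhibitor of growth, a higher number a weaker inhibitor of growth), with 48300 nM. Among the measured compounds shown here, its nearest measured neighbour is compound 1 `O=C1C(=O)N(CN2CCN(c3ccnc4cc(Cl)ccc34)CC2)c2cc(Cl)ccc21`, which gives 26100 nM; the single measured step, a 1.9-fold higher number from compound 1 to compound 2 (0.27 log units; within the scatter), is hydrogen in place of chloro on an aromatic carbon and lies within the scatter. Compound 3 `O=C1C(=O)N(CN2CCN(c3ccnc4cc(C(F)(F)F)ccc34)CC2)c2ccccc21` differs from compound 2 by trifluoromethyl in place of chloro on an aromatic carbon, the trifluoromethyl sitting on the six-membered aromatic ring of carbon only within the fused system of two rings. For the measured compounds named here, no measured step bears directly on this exchange: the one recorded step, a 1.9-fold higher number from compound 1 to compound 2 (0.27 log units; within the scatter), concerns a different chloro and was itself within the scatter. With nothing pointing either way, the change is expected to give a 1.1-fold lower number from compound 2 to compound 3 (0.03 log units; within the scatter), nothing beyond the scatter. Compound 3 is therefore estimated at 45000 nM, within a range from 18000 nM to 110000 nM.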

Compound 3, concentration for 50% growth inhibition: 34000 nM
Compound 3: the middle estimate sits 1.3-fold (0.12 log units) above what was measured; measured number inside the range.
By their numbers in this assay, from the lowest: compounds 1, 3 and 2 (each within the scatter of the next).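

In this assay, among these compounds, the exchange on the six-membered aromatic ring of carbon only gives a 1.4-fold lower number from compound 2 to compound 3 (0.15 log units; within the scatter) and is the first step read at this position, since the earlier step concerned a chloro elsewhere in the molecule. Trifluoromethyl, with four heavy atoms, therefore stands in place of the single chlorine with no difference that can be told from the scatter. No measurement of any property of these groups accompanies the result, so the data offer no explanation for it.

The compounds shown leave open whether an amine or a carboxylic acid at this position would move the number beyond the scatter. They also leave open what hydrogen there would do, and whether any exchange at this position would matter more with a chloro also present on the other part of the core.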